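Butyl to Phenyl: Estimating Compound 3

The source may report more compounds than this note shows. Statements on the series, on what has been measured and on what is new or still open speak of the compounds shown alone.

Compound 1, `CCCCCCCCS(=O)(=O)Nc1ccc(-c2ccc(Cl)cc2)cc1C(=O)O`, gives 9200 nM in an assay on mitochondria (strain BALB/c) for inhibition of glycerol-3-phosphate acyltransferase 1, mitochondrial (Mus musculus), read by scintillation counting, with a stated time of 10 min; on this read-out lower numbers stand for stronger inhibition and higher numbers for weaker inhibition. Compound 2, `CCCCCCCCS(=O)(=O)Nc1ccc(-c2ccc(CCCC)cc2)cc1C(=O)O`, gives 9000 nM in this assay.

Compound 2 sits alongside compound 1 rather than apart from it: a 1.0-fold lower number from compound 1 to compound 2 (0.01 log units; within the scatter). Compound 3, `CCCCCCCCS(=O)(=O)Nc1ccc(-c2ccc(-c3ccccc3)cc2)cc1C(=O)O`, differs from compound 2 by phenyl in place of butyl on an aromatic carbon. Among the measured compounds shown here, the only measured step, a 1.0-fold lower number from compound 1 to compound 2 (0.01 log units; within the scatter), also changed the group at this place and moved the number not at all beyond the scatter, so the expectation for compound 3 in this assay is a step of no real size in either direction. Compound 3 is therefore estimated at 9000 nM, with a range from 4500 nM to 18000 nM, which means an expected step of no change at the digits printed from compound 2 to compound 3 (within the scatter).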

Compound 3, half-maximal inhibitory concentration: 29100 nM
Compound 3: the middle estimate sits 3.2-fold (0.51 log units) below what was measured; measured number outside the range, above it.
By their numbers in this assay, from the lowest: compounds 2 and 1 (each within the scatter of the next); then compound 3.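

On this position, in this assay, the group does matter: phenyl in place of butyl gives (a 3.2-fold higher number from compound 2 to compound 3 (0.51 log units; beyond the scatter)), and phenyl in place of chloro gives (a 3.2-fold higher number from compound 1 to compound 3 (0.50 log units; beyond the scatter)). Chloro and butyl read alike, so only the six-membered aromatic ring has so far weakened inhibition here. Nothing available explains this loss.

Still open, as far as these compounds go, is whether the loss follows the aromatic ring or simply the larger group, which cyclohexyl or a longer chain such as hexyl could help separate. From the compounds shown here alone, how an amine or a carboxylic acid would read here is also open.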